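A few compounds are considered here, and "the series" means these few. Any claim that something is new, unique, unknown or untested is made for them only; others in the source may bear on it.

Compound 1 `CC1(C)Oc2ccc(C#N)cc2[C@@H](/N=C(\NC#N)NCc2ccccc2)[C@@H]1O` is the stronger of the two compounds measured in a functional assay (aorta) with Rattus norvegicus as the target; a lower number here means a stronger inhibitor, a higher number a weaker inhibitor: compound 1 gives 2400 nM, while compound 2 `CC1(C)Oc2ccc(C#N)cc2[C@@H](N2CCN(c3ccccc3)C2=O)[C@@H]1O` gives 23700 nM, a gap beyond the usual scatter. Compound 3 `CSc1ccc(N/C(=N/[C@@H]2c3cc(C#N)ccc3OC(C)(C)[C@H]2O)NC#N)cc1` has not yet been measured. It differs from compound 1 in one place: 4-(methylsulfanyl)phenyl in place of benzyl on an amine nitrogen. Among the compounds with values here, with no measured pair showing this kind of change, the step from compound 1 to compound 3 in this assay is expected to be small, a 1.6-fold lower number from compound 1 to compound 3 (0.20 log units; within the scatter), and possibly within the scatter. Compound 3 is therefore estimated at 1500 nM, with a likely range from 400 nM to 6000 nM.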

Compound 3, half-maximal inhibitory concentration: 6300 nM
Compound 3: the middle estimate sits 4.2-fold (0.62 log units) below what was measured; the whole stated range lies below it.
By their numbers in this assay, from the lowest: compound 1; then compound 3; then compound 2.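

At this amine nitrogen the choice of group matters in this assay: 4-(methylsulfanyl)phenyl in place of benzyl gives a 2.6-fold higher number from compound 1 to compound 3 (0.42 log units; beyond the scatter), so this change weakens inhibition rather than improving it. No measurement at hand explains the step. The change also does two things at once, dropping the carbon that links the ring to the nitrogen and adding methylsulfanyl to the ring. A plain phenyl on the same nitrogen would separate these two parts, and a 4-methoxyphenyl would show whether another group in the place of methylsulfanyl behaves alike.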